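Chloro for Methyl on the Amino-Bearing Ring

The compounds below may be only part of what the source reports. "The series", "measured", "known", "first", "only" and "open" are said of these compounds alone.

Measured so far in a functional assay on MCF7 cells (Homo sapiens) for inhibition, read by CCK-8 assay, with a stated time of 48 h; on this read-out lower numbers stand for stronger inhibition and higher numbers for weaker inhibition:
Compound 1, `Cc1ccc(NC(=S)NC(=O)c2cn(-c3ccccc3)nc2-c2ccc(F)cc2)cc1`, gives 5440 nM.
Compound 2, `Cc1ccc(NC(=S)NC(=O)c2cn(-c3ccccc3)nc2-c2ccc(Cl)cc2)cc1`, gives 5980 nM.
Compound 3, `Cc1ccc(NC(=S)NC(=O)c2cn(-c3ccccc3)nc2-c2ccccc2)cc1`, gives 5900 nM.

None of the three can be set apart: a 1.1-fold higher number from compound 1 to compound 2 (0.04 log units; within the scatter), a 1.1-fold higher number from compound 1 to compound 3 (0.04 log units; within the scatter) and a 1.0-fold lower number from compound 2 to compound 3 (0.01 log units; within the scatter) all sit inside the usual scatter, so compound 1 stands level with compounds 2 and 3 rather than ahead of them.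

Compound 4, `O=C(NC(=S)Nc1ccc(Cl)cc1)c1cn(-c2ccccc2)nc1-c1ccc(F)cc1`, differs from compound 1 by chloro in place of methyl on an aromatic carbon, that is, 4-methylphenyl becomes 4-chlorophenyl on the (4-methylphenyl)amino side. Every measured step instead changed the other six-membered aromatic ring of the shared core, and each of those swaps, fluoro, chloro or hydrogen, left this assay unmoved. For the measured compounds named here, no step has yet probed the amino-bearing ring, so the expectation for compound 4 is a change no larger than the scatter, a 1.0-fold higher number from compound 1 to compound 4 (0.01 log units; within the scatter). Compound 4 is therefore estimated at 5600 nM, ranging from 2500 nM to 12500 nM.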

Compound 4, half-maximal inhibitory concentration: 5470 nM
Compound 4: the middle estimate sits 1.0-fold (0.01 log units) above what was measured; measured number inside the range.
By their numbers in this assay, from the lowest: compounds 1, 4, 3 and 2 (each within the scatter of the next).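

For the compounds shown here, the first change on the amino-bearing ring, 4-chlorophenyl in place of 4-methylphenyl, gives a 1.0-fold higher number from compound 1 to compound 4 (0.00 log units; within the scatter) in this assay and so shows that this ring, like the other ring changed earlier, can take this swap with no readable difference. Chloro and methyl cannot be told apart at this position, and no supporting data explain this sameness.

From the compounds shown here alone, whether other groups at this position would also read alike stays open, such as an amine or a carboxylic acid. The same holds for plain hydrogen there, or a longer chain.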